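Halogen Swap on the Aryl Ring of Compound 2

A few compounds are considered here, and "the series" means these few. Any claim that something is new, unique, unknown or untested is made for them only; others in the source may bear on it.

Measured compounds:
compound 1 `O=C1N=C(N2N=C(c3ccc(Cl)cc3)CC2c2ccc(Cl)cc2)S/C1=C1\C(=O)Nc2ccccc21`, 68200 nM
compound 2 `O=C1N=C(N2N=C(c3ccc(Cl)cc3)CC2c2ccc(Cl)cc2)S/C1=C1\C(=O)Nc2ccc(Br)cc21`, 730 nM
compound 3 `O=C1N=C(N2N=C(c3ccccc3)CC2c2ccc(Cl)cc2)S/C1=C1\C(=O)Nc2ccccc21`, "not determined" (no result reported)

In a functional assay on Mino cells (Homo sapiens) for cytotoxicity, read by MTT assay, with a stated time of 72 h (on this read-out lower numbers stand for stronger inhibition and higher numbers for weaker inhibition), compound 1 gives 68200 nM, while compound 2 gives 730 nM. The step of a 93-fold lower number from compound 1 to compound 2 (1.97 log units; beyond the scatter) is large and arises from a bromo in place of hydrogen on an aromatic carbon. For compound 3 the entry reads "not determined" (no result reported). Compound 2 therefore stands lowest of the two numbers available, with compound 1 as its only comparator.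

Compound 4 `O=C1N=C(N2N=C(c3ccc(Br)cc3)CC2c2ccc(Cl)cc2)S/C1=C1\C(=O)Nc2ccc(Br)cc21` differs from compound 2 by bromo in place of chloro on an aromatic carbon. For the measured compounds named here, no measured step of this kind is available: the single step known concerns a different position and a different pair of groups, so it does not bear directly on this change. Exchanging one halogen for another on the same aromatic carbon is expected to move the number little, if at all, in this assay. The estimate for compound 4 is 650 nM, with a range from 220 nM to 2000 nM, so the expected step of a 1.1-fold lower number from compound 2 to compound 4 (0.05 log units; within the scatter) lies within the scatter.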

Compound 4, half-maximal inhibitory concentration: 270 nM
Compound 4: the middle estimate sits 2.4-fold (0.38 log units) above what was measured; low and high end bracket the measured number.
By their numbers in this assay, from the lowest: compound 4; then compound 2; then compound 1.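

In this assay, 4-bromophenyl in place of 4-chlorophenyl gives a 2.7-fold lower number from compound 2 to compound 4 (0.43 log units; beyond the scatter) and so counts as a modest step. For the compounds shown here, until now the only readable change was bromo in place of hydrogen at another place in the molecule, so this is the first sign that the number also responds at this second place. It also shows that exchanging one halogen for another on an aromatic carbon, and not only adding a halogen where hydrogen stood, can move the number beyond the scatter. Nothing in the data given accounts for this step.

This single pair does not show how fluoro, iodo, methoxy or an amine would behave on this aromatic carbon. It also leaves open whether the other 4-chlorophenyl group would respond to bromo in the same way.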